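Chloro on the Fused Ring: A Second Test

The source may report more compounds than this note shows. Statements on the series, on what has been measured and on what is new or still open speak of the compounds shown alone.

Measured so far:
compound 1, `CC(=O)N1N=C(Nc2nc3ccc(Cl)cc3s2)CC1c1ccccc1`, 161 umol/kg
compound 2, `CC(=O)N1N=C(Nc2nc3ccccc3s2)CC1c1ccccc1`, 315 umol/kg
compound 3, `O=C(/C=C/c1ccccc1)Nc1nc2ccccc2s1`, 646 umol/kg

All three were tested in a functional assay on the whole organism (Hindlimb, strain albino) with Mus musculus as the target, in the maximal electroshock model, with a stated time of 0.5 h; a lower number here means that less compound is needed, a higher number that more compound is needed for the effect. Compound 1 differs from compound 2 by chloro in place of hydrogen on an aromatic carbon, and this gave a 2.0-fold lower number from compound 2 to compound 1 (0.29 log units; within the scatter). Compound 3 carries a different core; how its core differs from that of compound 2 is not broken down here. In this assay compound 3 gives 646 umol/kg, the highest of the three numbers.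

Compound 4, `O=C(/C=C/c1ccccc1)Nc1nc2ccc(Cl)cc2s1`, is not yet measured. It differs from compound 3 by chloro in place of hydrogen on an aromatic carbon, the same change, at the same place, as that from compound 2 to compound 1. Going by the values given here, from compound 3 to compound 4 in this assay the expected step is a 2.0-fold lower number from compound 3 to compound 4 (0.31 log units; beyond the scatter), resting on the one earlier example, a 2.0-fold lower number from compound 2 to compound 1 (0.29 log units; within the scatter), which is itself within the scatter, so the step could also be nil. The estimate for compound 4 is therefore 320 umol/kg, with a range from 160 umol/kg to 650 umol/kg.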

Compound 4, dose for half-maximal effect: 425 umol/kg
Compound 4: middle estimate off by 1.3-fold (0.12 log units), on the low side; low and high end bracket the measured number.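

In this assay, chloro in place of hydrogen on an aromatic carbon gives a 1.5-fold lower number from compound 3 to compound 4 (0.18 log units; within the scatter). Set beside the earlier case, the change gives steps on the two cores that cannot be told apart: the same change on two cores in this assay, a 2.0-fold lower number (0.29 log units; within the scatter) from compound 2 to compound 1 and a 1.5-fold lower number (0.18 log units; within the scatter) from compound 3 to compound 4, 1.3-fold (0.11 log units) apart, within the scatter of two such steps. Each step on its own also lies within the scatter, so this pair does not show that chloro truly changes the dose needed, and two cores are too few to say what the same change would do on a third.

The compounds shown carry only hydrogen or chloro at this place, which leaves open whether fluoro, bromo, a methoxy group or an amine there would give a step of similar size. Chloro also appears at just this one carbon, so what it would do on the other carbons of the same six-membered ring remains open too.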